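A Bromo Group Enters a Weak Dioxygenase Inhibitor

A few compounds are considered here, and "the series" means these few. Any claim that something is new, unique, unknown or untested is made for them only; others in the source may bear on it.

Measured so far, all in an assay for inhibition of Indoleamine 2,3-dioxygenase 1 (Homo sapiens), read by spectrophotometry, with a stated time of 180 min, tested at 10 uM; a lower number here means a weaker effect, a higher number a stronger effect of the compound at the concentration tested:
compound 1, `O=C(O)c1ccc(CNc2cccc3[nH]ncc23)cc1`, 1%
compound 2, `O=C(O)c1cc(CNc2cc(Br)cc3[nH]ncc23)ccc1O`, 38%
compound 3, `Oc1ccccc1CNc1cc(Br)cc2[nH]ncc12`, 41%

Compound 1 stands at the bottom of these three numbers. In this assay compound 1 gives 1%, while compound 2 gives 38% and compound 3 gives 41%; both of those gaps lie beyond the usual scatter of repeated measurements, so compound 1 is clearly the weakest of the three.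

The piece now follows the step from compound 1 to compound 4, `O=C(O)c1ccc(CNc2cc(Br)cc3[nH]ncc23)cc1`, which has not yet been measured in this assay. The change is small: bromo in place of hydrogen on an aromatic carbon. Compound 2 and compound 3 both carry a bromo group and both score higher than compound 1, but each of them also differs from compound 1 in other places, so no single change between measured compounds isolates the effect of the bromo group alone.

On that basis compound 4 is expected to rise moderately, with a number 17 percentage points higher from compound 1 to compound 4 (beyond the scatter) as the estimated step. Compound 4 is expected to give about 18%, within a range of 0% to 40%.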

Compound 4, a percentage reported as inhibition, at one concentration (the size of the read-out at that concentration, not a potency): 49%
For compound 4 the middle estimate is 31 percentage points below the measured one, outside the stated range (above it).
By their numbers in this assay, from the lowest: compound 1; then compounds 2, 3 and 4 (each within the scatter of the next, the first and the last beyond it).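

For the compounds shown here, putting bromo in place of hydrogen on an aromatic carbon of the fused system gives a number 48 percentage points higher from compound 1 to compound 4 (beyond the scatter) in this assay, the first step in this set where one change stands alone. Compound 1 and compound 4 differ in that one place only, so the whole gain belongs to this exchange of a hydrogen atom for 1 heavy atom, at the carbon that lies para to a fused ring and meta to a large group. This position therefore matters to the read-out at the single concentration tested, although the data give no reason for the gain, and no measurement at hand bears on its cause.

What the compounds shown leave open is whether bromo itself is needed, or whether chloro, methyl or methoxy at the same carbon would give a similar rise. They also leave open whether any group at the other carbons of that ring would do the same, and the remaining comparisons among these compounds cannot be read as single changes.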